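The source may report more compounds than this note shows. Statements on the series, on what has been measured and on what is new or still open speak of the compounds shown alone.

Measured so far, in a functional assay on MIA PaCa-2 cells (Homo sapiens) for antiproliferative activity, read by MTT assay, with a stated time of 72 h; a higher number here means that more compound is needed for the effect, a lower number that less compound is needed:
compound 1, `CNC(=O)c1cccc(Cn2nc(C)c(NC(=O)c3ccc(COc4ccccc4OC)cc3)c2C)c1`, 8500 nM;
compound 2, `CNC(=O)c1cccc(Cn2nc(C)c(NC(=O)c3ccc(COc4ccc(Cl)cc4)cc3)c2C)c1`, 4200 nM;
compound 3, `CNC(=O)c1cccc(Cn2nc(C)c(NC(=O)c3ccc(COc4ccccc4C(F)(F)F)cc3)c2C)c1`, 10000 nM.

Compound 3 holds the highest of the three numbers. Going by the values given here, its gap to compound 1 is within the scatter, so the two cannot be told apart; the step of a 2.4-fold higher number from compound 2 to compound 3 (0.38 log units; beyond the scatter) is the only one that separates compound 3 from another compound. Compound 4, `CNC(=O)c1cccc(Cn2nc(C)c(NC(=O)c3ccc(COc4cccc(C(F)(F)F)c4)cc3)c2C)c1`, differs from compound 3 by 3-(trifluoromethyl)phenyl in place of 2-(trifluoromethyl)phenyl on an oxygen on a saturated carbon. Among the compounds with values here, no measured step moves the same group around a ring; the nearest points of reference are a 1.2-fold higher number from compound 1 to compound 3 (0.07 log units; within the scatter), a swap of groups at one place, and a 2.4-fold higher number from compound 2 to compound 3 (0.38 log units; beyond the scatter), a swap of whole aryl groups. Both stay near the scatter. The step of a 1.3-fold lower number from compound 3 to compound 4 (0.12 log units; within the scatter) is therefore expected to be small or absent. Compound 4 is estimated at 7500 nM, with a range from 3000 nM to 18000 nM.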

Compound 4, half-maximal effective concentration: 2300 nM
Beside the measured number, compound 4's estimate is 3.3-fold (0.51 log units) above it; measured number below the stated range.
By their numbers in this assay, from the lowest: compounds 4 and 2 (each within the scatter of the next); then compounds 1 and 3 (each within the scatter of the next).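

Moving the trifluoromethyl group around the phenyl ring, with no atom gained or lost, gives a 4.3-fold lower number from compound 3 to compound 4 (0.64 log units; beyond the scatter) and so shows that where the group sits on this ring matters, which no earlier step could show. The new group also gives a 3.7-fold lower number from compound 1 to compound 4 (0.57 log units; beyond the scatter) in a swap of whole aryl groups, while a 1.8-fold lower number from compound 2 to compound 4 (0.26 log units; within the scatter) leaves those two compounds indistinguishable. Nothing available explains why the position matters. The compounds shown leave open how an amine or a carboxylic acid on this ring would compare.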